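Carbamate series: cytotoxicity readings and one untested analogue

A few compounds are considered here, and "the series" means these few. Any claim that something is new, unique, unknown or untested is made for them only; others in the source may bear on it.

Compound 1 `O=C(NCc1ccc(OC(F)(F)F)cc1)OCC1CCn2cc([N+](=O)[O-])nc2O1`: in an ADME assay on MRC5 cells (Homo sapiens) for cytotoxicity, read by resazurin assay, with a stated time of 72 h (on this read-out lower numbers stand for stronger inhibition and higher numbers for weaker inhibition), compound 1 gives >= 40000 nM, a limit of the assay.
Compound 2 `CC1(COC(=O)NCc2ccc(OC(F)(F)F)cc2)CCn2cc([N+](=O)[O-])nc2O1`: in this assay compound 2 gives >= 40000 nM, again a limit.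
Compound 3 `O=C(NCc1ccc(OC(F)(F)F)cc1)N(Cc1ccc(OC(F)(F)F)cc1)C(=O)OCC1CCn2cc([N+](=O)[O-])nc2O1`: in this assay compound 3 gives >= 40000 nM, also a limit.

From compound 1 to compound 2 the change is methyl in place of hydrogen on a saturated ring carbon, and the step that the two limits leave unreadable from compound 1 to compound 2 cannot be sized, since both readings are limits. The difference between the core of compound 1 and the core of compound 3 is not broken down here. Compound 4 `CC1(COC(=O)N(Cc2ccc(OC(F)(F)F)cc2)C(=O)NCc2ccc(OC(F)(F)F)cc2)CCn2cc([N+](=O)[O-])nc2O1` differs from compound 3 by methyl in place of hydrogen on a saturated ring carbon, the same change as from compound 1 to compound 2. All that is known of the measured compounds is the limit of >= 40000 nM in this assay, at which 3 of the 3 values shown sit.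

For compound 4 the step of a number no higher from compound 3 to compound 4 (the limit leaves the size open) is expected to stay unreadable in the same way, because every reading so far sits at the limit of >= 40000 nM in this assay, at which 3 of the 3 values shown sit. Compound 4 is therefore estimated at 40000 nM in this assay, most probably reported as a limit once more.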

Compound 4, half-maximal inhibitory concentration: >= 40000 nM
Compound 4 ended at the assay's limit; the forecaster's own chance of this, stated with the estimate: 85%; the middle value lies on the limit itself.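

No new step can be read from compound 3 to compound 4, because both readings are limits: the limit of >= 40000 nM in this assay, at which 4 of the 4 values shown sit. The compounds shown leave open whether methyl in place of hydrogen on a saturated ring carbon shifts the read-out at all.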